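This account rests on a few compounds, and the source may have more. Where it says the series, first, only, none or still open, it means among the compounds named here.

Measured so far in an assay on HeLa cells for inhibition of sphingosine-1-phosphate transporter SPNS2 (Mus musculus), read by LC-MS, tested at 2 uM; on this read-out higher numbers stand for more inhibition at the one concentration tested (going by the name of the read-out) and lower numbers for less inhibition:
compound 1, `CCCCCCCCCCc1ccc(-c2noc(C3CNC3)n2)cc1`, gives 65%
compound 2, `CCCCCCCCCCc1ccc(-c2noc(CCCNC)n2)cc1`, gives 45%
compound 3, `CCCCCCCCCCc1ccc(-c2noc(CC3CCNC3)n2)cc1`, gives 44%

Compound 3 sits at the low end of the three numbers shown. Its difference from compound 2, a number 1 percentage points lower from compound 2 to compound 3 (within the scatter), is within the scatter, so nothing separates the two; its difference from compound 1, a number 21 percentage points lower from compound 1 to compound 3 (beyond the scatter), is beyond the scatter.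

Compound 4, `CCCCCCCCCCc1ccc(-c2noc([C@@H]3CCNC3)n2)cc1`, differs from compound 3 by pyrrolidin-3-yl in place of (pyrrolidin-3-yl)methyl on an aromatic carbon. For the measured compounds named here, the step that bears most directly on this is the one from compound 1 to compound 3, a number 21 percentage points lower from compound 1 to compound 3 (beyond the scatter), in which (pyrrolidin-3-yl)methyl took the place of azetidin-3-yl on the aromatic carbon and the number dropped. Compound 4 reverses part of that move: it keeps the five-membered ring but puts it directly on the aromatic carbon, as compound 1 does. The step from compound 1 to compound 2, a number 20 percentage points lower from compound 1 to compound 2 (beyond the scatter), points the same way, with a group on a chain carbon again giving the lower number. A modest rise is therefore expected for compound 4, a number 14 percentage points higher from compound 3 to compound 4 (beyond the scatter), without reaching beyond the figure of compound 1. The estimate for compound 4 in this assay is 58%, with a range from 44% to 72%.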

Compound 4, a percentage reported as inhibition, at one concentration (the size of the read-out at that concentration, not a potency): 62%
The estimate for compound 4 lay 4 percentage points below the measured number, and the stated range covers the measured number.
By their numbers in this assay, from the lowest: compounds 3 and 2 (each within the scatter of the next); then compounds 4 and 1 (each within the scatter of the next).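

Working notes on the series, read in this assay: with the ring kept, pyrrolidin-3-yl in place of (pyrrolidin-3-yl)methyl gives a number 18 percentage points higher from compound 3 to compound 4 (beyond the scatter), so at this position on the aromatic carbon the direct attachment of the ring, rather than the five-membered ring itself, goes with the change in the number. The same group set against 3-(methylamino)propyl gives a number 17 percentage points higher from compound 2 to compound 4 (beyond the scatter), while against azetidin-3-yl it gives a number 3 percentage points lower from compound 1 to compound 4 (within the scatter), so the two directly attached rings are not separated here, and among the four compounds none goes against the split between directly attached rings and the two groups joined through a saturated chain carbon. No measurement shown gives a reason for these steps.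

On these data alone, it stays open whether the mirror-image form of the pyrrolidin-3-yl group in compound 4 gives a similar number, and whether a directly attached piperidin-4-yl would stay with the two smaller rings. A carboxylic acid in place of the ring amine would test whether the amine is needed at this position at all.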